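Two amides at the assay limit and a cyanobenzyl variant

The source may hold more compounds than are shown below. What is called first, only, known or untested is meant among the compounds shown, and "the series" means these compounds.

Measured compounds:
compound 1 `CC(C)n1ncc2c(C(=O)NCc3cn(-c4ccccc4F)nn3)cccc21` — > 40000 nM
compound 2 `CC(C)n1ncc2c(C(=O)NCc3cn(-c4ccc(C(F)(F)F)cc4)nn3)cccc21` — > 40000 nM

In a functional assay on MGC-803 cells (Homo sapiens) for inhibition, read by MTT assay, with a stated time of 72 h (on this read-out higher numbers stand for weaker inhibition and lower numbers for stronger inhibition), compound 1 gives only a limit, > 40000 nM. Compound 2 likewise gives only a limit, > 40000 nM. The step that the two limits leave unreadable from compound 1 to compound 2 is therefore unreadable, and compound 2 stands at the limit of > 40000 nM in this assay, at which 2 of the 2 values shown sit. Compound 3 `CC(C)n1ncc2c(C(=O)NCc3cn(Cc4ccc(C#N)cc4)nn3)cccc21` differs by 4-cyanobenzyl in place of 4-(trifluoromethyl)phenyl on an aromatic nitrogen. Among the measured compounds shown here, no measured step bears readably on this change. Compound 3 is expected to give 40000 nM, within 10000 nM to 100000 nM, most likely again as a limit. The expected step of a number no higher from compound 2 to compound 3 (the limit leaves the size open) is thus estimated as none beyond the scatter.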

Compound 3, half-maximal inhibitory concentration: 39600 nM
Estimate against measurement, compound 3: 1.0-fold (0.00 log units) above, within the range that was stated.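

In this assay compound 3, with 4-cyanobenzyl on the aromatic nitrogen, is the only one of the three compounds shown that gives a number rather than a limit, and the data show a number no higher from compound 2 to compound 3 (the limit leaves the size open) and a number no higher from compound 1 to compound 3 (the limit leaves the size open). The other two values are limits of the assay, not numbers: the limit of > 40000 nM in this assay, at which 2 of the 3 values shown sit. The sizes of these two steps therefore cannot be read, and no size can be given for this change. The compounds shown leave open whether the benzyl link or the nitrile matters on its own. They also leave open whether an amine or a carboxylic acid in place of the nitrile would give a lower number.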